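Benzyl amide variants on the shared core

The compounds below may be only part of what the source reports. "The series", "measured", "known", "first", "only" and "open" are said of these compounds alone.

Measured so far:
compound 1, `CCCN(C)C(=O)c1cc2c(Cc3ccccc3)n[nH]c2cc1O`: > 10000 nM
compound 2, `CN(Cc1ccccc1Br)C(=O)c1cc2c(Cc3ccccc3)n[nH]c2cc1O`: 1200 nM

In a functional assay on A2780 cells (Homo sapiens) for antiproliferative activity, read by resazurin assay, with a stated time of 72 h (a lower number here means a stronger inhibitor, a higher number a weaker inhibitor), compound 1 gives > 10000 nM, which is a limit of the assay and not a number (the limit of > 10000 nM in this assay, at which 1 of the 2 values shown sits). Compound 2 gives 1200 nM in this assay. Within the data shown here, the one measured step, an at least 8.3-fold lower number from compound 1 to compound 2 (0.92 log units; beyond the scatter), is the only guide for the unmeasured compound 3, `CCOc1ccc(CN(C)C(=O)c2cc3c(Cc4ccccc4)n[nH]c3cc2O)cc1`, which differs from compound 1 as follows: 4-ethoxyphenyl in place of ethyl on a saturated chain carbon bound to an amide-type nitrogen. Both changes bring a substituted phenyl onto the same saturated chain carbon, so a step of comparable direction and size is expected, with the 4-ethoxyphenyl group untested and the true size open. Compound 3 is therefore expected to show a lower number than compound 1, the step of an at least 6.6-fold lower number from compound 1 to compound 3 (0.82 log units; beyond the scatter) being the estimate. Compound 3 is estimated at 1500 nM, within 500 nM to 6000 nM.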

Compound 3, half-maximal inhibitory concentration: 3200 nM
For compound 3 the middle estimate is 2.1-fold (0.33 log units) below the measured one, within the range that was stated.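

In this assay, a second substituted phenyl on the saturated chain carbon bound to the amide-type nitrogen again lowers the number, with an at least 3.1-fold lower number from compound 1 to compound 3 (0.49 log units; beyond the scatter), so the drop is not confined to the 2-bromophenyl group of compound 2. The two phenyl groups are not interchangeable at this place, as 4-ethoxyphenyl in place of 2-bromophenyl gives a 2.7-fold higher number from compound 2 to compound 3 (0.43 log units; beyond the scatter). The value of compound 1 is a limit of the assay and not a number: the limit of > 10000 nM in this assay, at which 1 of the 3 values shown sits.

The two phenyl groups differ both in the substituent and in where it sits, so the shown compounds cannot separate these two changes. Open too, as far as these compounds go, is how an unsubstituted phenyl, a 4-bromophenyl, a 2-ethoxyphenyl, or a phenyl carrying an amine or a carboxylic acid would read at this place.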